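Thiophene to Furan on the Amine Side Chain

The source may hold more compounds than are shown below. What is called first, only, known or untested is meant among the compounds shown, and "the series" means these compounds.

Compound 2 `c1ccc(C(c2ccccc2)[C@@H]2CC[C@H](NCc3cccs3)CO2)cc1` shows 41.4 nM in an assay on striatum for inhibition of sodium-dependent dopamine transporter (Rattus norvegicus) (on this read-out higher numbers stand for weaker inhibition and lower numbers for stronger inhibition), the highest of the two numbers at hand; its nearest neighbour is compound 1 `Oc1cccc(CN[C@H]2CC[C@@H](C(c3ccccc3)c3ccccc3)OC2)c1`, which gives 31.3 nM in this assay. Among the compounds with values here, the one step between them, a 1.3-fold higher number from compound 1 to compound 2 (0.12 log units; within the scatter), stays within the scatter. Compound 3 `c1ccc(C(c2ccccc2)[C@@H]2CC[C@H](NCc3ccco3)CO2)cc1` is not yet measured; it differs from compound 2 by furan-2-yl in place of thiophen-2-yl on a saturated chain carbon bound to an amine nitrogen. Within the data shown here, only the step from compound 1 to compound 2 bears on this change, and it showed nothing beyond the scatter, so one exchange of a small aromatic ring on this chain carbon has so far moved the number little. The step from compound 2 to compound 3 is therefore expected to be small, a 1.3-fold higher number from compound 2 to compound 3 (0.12 log units; within the scatter), with no direction beyond the scatter claimed. For compound 3 the estimate in this assay is 55 nM, with a range from 25 nM to 120 nM.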

Compound 3, inhibition constant: 110 nM
Compound 3: the middle estimate sits 2.0-fold (0.30 log units) below what was measured, within the range that was stated.
By their numbers in this assay, from the lowest: compounds 1 and 2 (each within the scatter of the next); then compound 3.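

In this assay, the place on a saturated chain carbon bound to an amine nitrogen proved sensitive to an exchange between two five-membered aromatic rings with 1 hetero atom (a 2.7-fold higher number from compound 2 to compound 3 (0.42 log units; beyond the scatter)), although thiophen-2-yl and furan-2-yl have the same count of heavy atoms and differ only in sulfur against oxygen. Where 3-hydroxyphenyl and thiophen-2-yl had stayed within the scatter of each other, furan-2-yl in place of 3-hydroxyphenyl also moved the number beyond it (a 3.5-fold higher number from compound 1 to compound 3 (0.55 log units; beyond the scatter)), so furan-2-yl alone stands apart among the three groups. Nothing at hand accounts for this difference.

The compounds shown leave open how an unsubstituted phenyl, a pyridin-2-yl or a thiophen-3-yl group would compare at this place. They also leave open whether a longer chain to the thiophen-2-yl or furan-2-yl ring would keep the same gap.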